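Swapping dimethylamino for isopropylamino in compound 1

The source may report more compounds than this note shows. Statements on the series, on what has been measured and on what is new or still open speak of the compounds shown alone.

- compound 1 (`CN(C)C(=O)/C=C1\CCc2ccc(F)cc21`): > 100 mg/kg (a limit)
- compound 2 (`CN(C)C(=O)/C=C1\CCc2c(F)cc(F)cc21`): 50 mg/kg
- compound 3 (`CNC(=O)/C=C1\CCc2c(F)cc(F)cc21`): 45 mg/kg

In a functional assay on the whole organism with Mus musculus as the target (on this read-out lower numbers stand for an effect already at smaller amounts and higher numbers for an effect only at larger amounts of compound), compound 1 gives > 100 mg/kg as a limit of the assay, not a number. So compound 1 stands at the limit of > 100 mg/kg in this assay, at which 1 of the 3 values shown sits, and offers no exact starting point.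

Compound 4 (`CC(C)NC(=O)/C=C1\CCc2ccc(F)cc21`) keeps the core of compound 1 and puts isopropylamino in place of dimethylamino on a carbonyl carbon. Among the measured compounds shown here, no measured compound carries isopropylamino. The nearest measured change, hydrogen in place of methyl on an amide-type nitrogen, gave a small step (a 1.1-fold lower number from compound 2 to compound 3 (0.05 log units; within the scatter)). The other measured step (an at least 2.0-fold lower number from compound 1 to compound 2 (0.30 log units; that floor lies within the scatter)) concerns fluoro on an aromatic carbon, which compound 4 does not alter, so it does not bear on this change.

Resting on the amide step alone, no step beyond the scatter is expected in this assay (a number no higher from compound 1 to compound 4 (the limit leaves the size open)). The estimate for compound 4 is 100 mg/kg, expected to fall from 40 mg/kg to 250 mg/kg in four of five measurements.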

Compound 4, dose for half-maximal effect: 96 mg/kg
Compound 4: the middle estimate sits 1.0-fold (0.02 log units) above what was measured; the range from low to high includes it.
By their numbers in this assay, from the lowest: compounds 3, 2 and 4 (each within the scatter of the next, the first and the last beyond it). At a limit, above all of these: compound 1.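

On the core of compound 1, the carbonyl carbon carries isopropylamino and gives a number in this assay, which dimethylamino at that place did not give on this core. The change reads as an at least 1.0-fold lower number from compound 1 to compound 4 (0.01 log units; that floor lies within the scatter), so the data do not show that isopropylamino lowers the number beyond the usual scatter. The true size of this step stays open because the value for compound 1 is only a limit: the limit of > 100 mg/kg in this assay, at which 1 of the 4 values shown sits.

Still open, from the compounds shown here alone, is how other groups on the carbonyl carbon would read in this assay, such as ethylamino, a morpholine ring or a free carboxylic acid. Also open, going by these compounds, is what isopropylamino would give on the core of compound 2, with its added fluoro.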